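Bromophenol aldehyde to alcohol: cytotoxicity in endothelial cells

A few compounds are considered here, and "the series" means these few. Any claim that something is new, unique, unknown or untested is made for them only; others in the source may bear on it.

Compound 1, `COc1c(Br)cc(C=O)c(O)c1Br`: in an ADME assay on BAEC cells (Bos taurus) for cytotoxicity, read by MTT assay, with a stated time of 2 days (on this read-out lower numbers stand for stronger inhibition and higher numbers for weaker inhibition), compound 1 gives 806000 nM.
Compound 2, `COc1c(Br)cc(CO)c(O)c1Br`: in this assay compound 2 gives > 16000 nM, which is a limit of the assay.
Compound 3, `COc1c(Br)cc(C=O)c(OCc2ccccc2)c1Br`: in this assay compound 3 gives > 12500 nM, which is a limit of the assay.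

Compound 2 comes from compound 1 by hydroxymethyl in place of formyl on an aromatic carbon. The step that the limit leaves unreadable from compound 1 to compound 2 cannot be sized because of the limit of > 16000 nM in this assay, at which 1 of the 3 values shown sits. Compound 4, `COc1c(Br)cc(CO)c(OCc2ccccc2)c1Br`, is not yet measured; it comes from compound 3 by hydroxymethyl in place of formyl on an aromatic carbon, the same kind of change, though here the place is ortho to a group of 8 heavy atoms rather than ortho to a hydroxy group (1 heavy atom). How the core of compound 3 differs from the core of compound 1 is not broken down here. For compound 4 a step that the limit leaves unreadable from compound 3 to compound 4 is expected in this assay. This rests on compound 3 sitting at the limit of > 12500 nM in this assay, at which 1 of the 3 values shown sits. It also rests on compound 1 giving 806000 nM in this assay. Compound 4 is expected to give 400000 nM, between 40000 nM and 4000000 nM.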

Compound 4, half-maximal inhibitory concentration: > 12000 nM
Compound 4: only a limit was reported (the forecaster's own chance of this, stated with the estimate: 70%); the middle value lies beyond the limit too.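

In this assay, both compound 3 and compound 4 gave only limits, so no step can be read between them. The compounds shown leave open how far, if at all, hydroxymethyl in place of formyl shifts cytotoxicity.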